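This account rests on a few compounds, and the source may have more. Where it says the series, first, only, none or still open, it means among the compounds named here.

Of the compounds shown here, three built on the same fused two-ring core have been tested in a functional assay on MCF7 cells (Homo sapiens) for inhibition, read by fluorescence, with a stated time of 72 h; a lower number here means a stronger inhibitor of growth, a higher number a weaker inhibitor of growth. Compound 1, `c1ccc(-n2cc3cnc(-c4ccsc4)cc3n2)cc1`, gives 9800 nM in this assay. Compound 2, `Cc1nc(CCO)cc2nn(-c3ccccc3)cc12`, carries a 2-hydroxyethyl group and a methyl group on the core, and in this assay compound 2 reaches only the limit of > 100000 nM, so no number is known for it. Compound 3, `Cn1cc2cnc(-c3ccccc3)cc2n1`, likewise reaches only the limit of > 100000 nM in this assay. Compound 2 therefore stands at the weak end of what has been seen so far: the limit of > 100000 nM in this assay, at which 2 of the 3 values shown sit. No pair of these compounds differs in a single place, so no measured step is available.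

Compound 4, `Cc1nc(-c2ccccc2)cc2nn(-c3ccccc3)cc12`, has not yet been measured. It differs from compound 2 in one place: phenyl in place of 2-hydroxyethyl on an aromatic carbon. Compound 1, which also carries an aromatic ring on the core, gives 9800 nM, a measurable number rather than a limit. Compound 4 is therefore expected to move from the limit toward a measurable number, with an expected step of an at least 5.0-fold lower number from compound 2 to compound 4 (0.69 log units; beyond the scatter) in the direction of stronger inhibition, though its size cannot be checked against any measured pair. The estimate for compound 4 is 20000 nM, with a range from 5000 nM to 100000 nM.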

Compound 4, concentration for 50% growth inhibition: 11000 nM
The estimate for compound 4 lay 1.8-fold (0.26 log units) above the measured number; measured number inside the range.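

For the compounds shown here, replacing 2-hydroxyethyl with phenyl on this aromatic carbon, next to the ring nitrogen, gives the only measured change at this position: in this assay the result is an at least 9.0-fold lower number from compound 2 to compound 4 (0.95 log units; beyond the scatter), so the group here clearly affects growth inhibition on this core. That step is only a lower bound, and the true gap could be larger, because compound 2 has a limit rather than a number: the limit of > 100000 nM in this assay, at which 2 of the 4 values shown sit. The swap changes several things at once, since a six-membered aromatic ring enters while a chain with a hydrogen-bond donor and acceptor leaves, and this one pair cannot show which of these changes matters.

A cyclohexyl ring, a plain butyl chain or an amine on the same carbon would help to separate the effect of the aromatic ring from the effect of losing the hydroxyl group. The role of the methyl group also remains open, as no step among the compounds shown changes it.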